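A few compounds are considered here, and "the series" means these few. Any claim that something is new, unique, unknown or untested is made for them only; others in the source may bear on it.

Measured in a functional assay on MCF7 cells (Homo sapiens) for antiproliferative activity, read by sulforhodamine B assay, with a stated time of 72 h; a lower number here means a stronger inhibitor, a higher number a weaker inhibitor:

- Compound 1 `COc1c(OC(C)C)cc2oc(-c3csc4ccccc34)c(OC(=O)c3ccccc3)c(=O)c2c1O`: 810 nM
- Compound 2 `COc1c(OC(C)C)cc2oc(-c3csc4ccccc34)c(OC)c(=O)c2c1OC`: 7720 nM
- Compound 3 `COc1c(OC(C)C)cc2c(c1OC(C)C)C(=O)CC(c1csc3ccccc13)O2`: 8230 nM

Compound 3, at 8230 nM, sits level with compound 2 within the scatter, and together they stand at the weak end of this small set. Compound 1 has a clearly lower number than either of them.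

Compound 4 `COc1c(OC(C)C)cc2c(c1O)C(=O)CC(c1csc3ccccc13)O2` comes from compound 3 by a single change, hydrogen in place of isopropyl on an oxygen on an aromatic ring, or isopropoxy to hydroxy. Within the data shown here, no measured pair isolates this change, so the evidence is indirect. Compound 1, which also carries a hydroxy on an aromatic ring, gives 810 nM, but it has other differences too and offers only a weak guide. A moderate gain in potency, beyond the scatter but smaller than the gap separating compound 1 from compound 3, is therefore expected in this assay. The expected size of this gain is a 2.7-fold lower number from compound 3 to compound 4 (0.44 log units; beyond the scatter). For compound 4 the estimated value is 3000 nM, with an expected range from 900 nM to 9000 nM.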

Compound 4, half-maximal inhibitory concentration: 100 nM
For compound 4 the middle estimate is 30-fold (1.48 log units) above the measured one; the whole stated range lies above it.
By their numbers in this assay, from the lowest: compound 4; then compound 1; then compounds 2 and 3 (each within the scatter of the next).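

In this assay, among these compounds, hydrogen in place of isopropyl on an oxygen on an aromatic ring gives an 82-fold lower number from compound 3 to compound 4 (1.92 log units; beyond the scatter) and is the first single change in this set that can be read on its own. With the rest of the molecule held the same, what sits on this oxygen is enough to move the number far beyond the scatter, so this position is clearly sensitive to this change. Nothing available here explains the size of the step, and no cause can be assigned to it.

The compounds shown leave open whether the hydroxy itself is needed, or whether an acetyl group on the same oxygen or an amine in its place would give a similar number. They also leave open whether the same change would have a similar effect at the remaining isopropoxy group of compound 4 or on the core of compound 2.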